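This account rests on a few compounds, and the source may have more. Where it says the series, first, only, none or still open, it means among the compounds named here.

Measured so far:
Compound 1 `Cc1nc(N)c2nc(-c3ccccc3)sc2n1`: in a functional assay on CHO cells for antagonist activity at adenosine receptor A2b (Homo sapiens), read by cAMP accumulation, with a stated time of 10 min (on this read-out higher numbers stand for weaker inhibition and lower numbers for stronger inhibition), compound 1 reaches only a limit, > 30000 nM.
Compound 2 `Nc1nc(-c2cccc(CO)c2)nc2sc(-c3ccccc3)nc12`: in this assay compound 2 likewise reaches only a limit, > 30000 nM.

Compound 2 therefore stands at the edge of what this assay can report; (the limit of > 30000 nM in this assay, at which 2 of the 2 values shown sit). Among the measured compounds shown here, the one measured step, a step that the two limits leave unreadable from compound 1 to compound 2, has both ends at that limit, so its size cannot be read. Compound 3 `N#Cc1cccc(-c2nc(N)c3nc(-c4ccccc4)sc3n2)c1` differs from compound 2 by cyano in place of hydroxymethyl on an aromatic carbon. For the measured compounds named here, no measured step bears on this change, so nothing beyond the scatter is expected. The expected step is a step that the limit leaves unreadable from compound 2 to compound 3. Compound 3 is estimated at 40000 nM, between 10000 nM and 150000 nM, most probably again only a limit.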

Compound 3, half-maximal inhibitory concentration: > 30000 nM
Compound 3 gave a limit, no number; the forecaster's own chance of this, stated with the estimate: 75%; the middle value does not contradict the limit.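

No step can be read among compound 1, compound 2 and compound 3, as each gives only a limit and no number: the limit of > 30000 nM in this assay, at which 3 of the 3 values shown sit. The compounds shown leave open whether any of these group changes alters inhibition in this assay, and by how much.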